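A few compounds are considered here, and "the series" means these few. Any claim that something is new, unique, unknown or untested is made for them only; others in the source may bear on it.

Compound 1 `CC(C)(C)c1ccc(C(=O)NCc2ccc(C(N)=O)cc2)cc1` gives 3800 nM in an assay on HeLa cells with Bile acid receptor (Homo sapiens) as the target, read by a luciferase reporter, with a stated time of 24 h; on this read-out higher numbers stand for an effect only at larger amounts of compound and lower numbers for an effect already at smaller amounts.
Compound 2 `CC(C)(C)c1ccc(C(=O)NCc2ccc(S(C)(=O)=O)cc2)cc1` gives 3800 nM in this assay.

On these numbers compound 2 stands level with compound 1 at the digits shown; the single measured step, no change at the digits printed from compound 1 to compound 2 (within the scatter), swapped one substituent at that position and stayed within the scatter. Compound 3 `CC(C)(C)c1ccc(C(=O)NCc2ccc(OCC(=O)O)cc2)cc1` carries carboxymethoxy in place of methylsulfonyl on an aromatic carbon. For the measured compounds named here, no measured step involves carboxymethoxy, so the only guide is that one exchange at this position left the read-out unchanged. The step of a 1.1-fold higher number from compound 2 to compound 3 (0.02 log units; within the scatter) is therefore expected to be small or none, with wide uncertainty. Compound 3 is estimated at 4000 nM, in the range 1000 nM to 16000 nM.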

Compound 3, half-maximal effective concentration: 730 nM
For compound 3 the middle estimate is 5.5-fold (0.74 log units) above the measured one; the measured number lies below the stated range.
By their numbers in this assay, from the lowest: compound 3; then compounds 1 and 2 (each within the scatter of the next).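

Placing carboxymethoxy on this aromatic carbon gave a 5.2-fold lower number from compound 2 to compound 3 (0.72 log units; beyond the scatter) in this assay and also a 5.2-fold lower number from compound 1 to compound 3 (0.72 log units; beyond the scatter), so the position does respond to its substituent, which the exchange of carbamoyl for methylsulfonyl alone had not shown. The read-out at this position therefore depends on which group is present, and at least one group takes it beyond the scatter. No measurement offered here explains this step.

From the compounds shown here alone, whether a methoxy group, a methyl ester or a longer chain ending in a carboxylic acid would give a similar number stays open. So does which part of carboxymethoxy accounts for the step.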